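Shifting the thiophene attachment on the shared core

The source may hold more compounds than are shown below. What is called first, only, known or untested is meant among the compounds shown, and "the series" means these compounds.

Compound 1: `O=c1[nH]cnc2c1c(-c1ccoc1)cn2[C@@H]1O[C@H](CO)[C@@H](O)[C@H]1O`, 6370 nM
Compound 2: `O=c1[nH]cnc2c1c(-c1cccs1)cn2[C@@H]1O[C@H](CO)[C@@H](O)[C@H]1O`, > 20000 nM

Compound 1 `O=c1[nH]cnc2c1c(-c1ccoc1)cn2[C@@H]1O[C@H](CO)[C@@H](O)[C@H]1O` carries a furan-3-yl group on the shared core. In a functional assay on HL-60 cells (Homo sapiens) for antiproliferative activity, read by XTT assay, with a stated time of 72 h (on this read-out higher numbers stand for weaker inhibition and lower numbers for stronger inhibition), compound 1 gives 6370 nM. Compound 2 `O=c1[nH]cnc2c1c(-c1cccs1)cn2[C@@H]1O[C@H](CO)[C@@H](O)[C@H]1O` carries thiophen-2-yl at the same place. In this assay compound 2 gives > 20000 nM, which is a limit of the assay and not a number (the limit of > 20000 nM in this assay, at which 1 of the 2 values shown sits). Going by the values given here, the step of an at least 3.1-fold higher number from compound 1 to compound 2 (0.49 log units; beyond the scatter) is the only measured step, and it changes both the heteroatom and the point of attachment at once, so it does not isolate either change.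

Compound 3 `O=c1[nH]cnc2c1c(-c1ccsc1)cn2[C@@H]1O[C@H](CO)[C@@H](O)[C@H]1O` is related to compound 2 by thiophen-3-yl in place of thiophen-2-yl on an aromatic carbon. The same atoms are joined differently; the move of the attachment point undoes one of the two changes that took compound 1 to compound 2, while keeping the sulfur. Since compound 2 is known only as a limit, the direction of this step cannot be read from a measured step. The number for compound 3 in this assay is expected to sit somewhat lower than the limit of compound 2, a step of an at least 1.6-fold lower number from compound 2 to compound 3 (0.22 log units; that floor lies within the scatter), with much uncertainty. Compound 3 is estimated at 12000 nM, between 4000 nM and 40000 nM.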

Compound 3, half-maximal inhibitory concentration: 12000 nM
Estimate against measurement, compound 3: no gap at the digits printed, within the range that was stated.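

At this place on the shared core, the new compound separates the two changes that the first step had combined. In this assay, the exchange of furan-3-yl for thiophen-3-yl gives a 1.9-fold higher number from compound 1 to compound 3 (0.28 log units; within the scatter), so this change of ring alone shows no difference that can be told from the scatter. Moving the attachment from thiophen-2-yl to thiophen-3-yl gives an at least 1.6-fold lower number from compound 2 to compound 3 (0.22 log units; that floor lies within the scatter), and since that floor lies within the scatter, the data do not yet establish that the point of attachment matters, although the true step could be larger; compound 2 is held only at a limit of the assay and not a number: the limit of > 20000 nM in this assay, at which 1 of the 3 values shown sits.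

On these data alone, what remains open is how far compound 2 truly sits from the other two, and whether furan-2-yl would follow thiophen-2-yl in the same way, which would test the point of attachment with the other ring. Also open, as far as these compounds go, is how groups of another kind on this aromatic carbon, such as a phenyl ring, an amine or a carboxylic acid, would read out in this antiproliferative measure.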